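Cytotoxicity notes on the series, from compound 3 to compound 4

A few compounds are considered here, and "the series" means these few. Any claim that something is new, unique, unknown or untested is made for them only; others in the source may bear on it.

Of the compounds shown here, three of the shared core have been tested in a toxicity assay on MDCK cells (Canis lupus familiaris) for cytotoxicity, read by crystal violet staining, with a stated time of 48 h; a lower number here means that less compound is tolerated, a higher number that more compound is tolerated. Compound 1 `Cc1ccc2cc(CN(Cc3ccc(C(C)C)cc3)Cc3ccccc3F)c(=O)[nH]c2c1` gives > 33000 nM in this assay, which is a limit of the assay and not a number. Compound 2 `CC(C)c1ccc2[nH]c(=O)c(CN(Cc3ccc(F)cc3)Cc3ccc(C(C)(C)C)cc3)cc2c1` gives 7900 nM in this assay. Compound 3 `Cc1ccc2[nH]c(=O)c(CN(Cc3ccc(OCC(=O)O)cc3)Cc3ccc(C(C)(C)C)cc3)cc2c1` gives > 10000 nM in this assay, again a limit rather than a number. Compound 3 thus stands at the limit of > 10000 nM in this assay, at which 1 of the 3 values shown sits. One further value of the three, that of compound 1, sits at the limit of > 33000 nM in this assay, at which 1 of the 3 values shown sits. Within the data shown here, only compound 2 yields a number, and no pair of measured compounds differs in a single place, so no measured step is available to anchor the change below.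

Compound 4 `Cc1ccc2[nH]c(=O)c(CN(Cc3ccc(C(C)(C)C)cc3)[C@H](CO)c3ccccc3)cc2c1` is the unmeasured member. Against compound 3 the change is 2-hydroxy-1-phenylethyl in place of 4-(carboxymethoxy)benzyl on an amine nitrogen. Nothing measured in this series speaks to this exchange. Since compound 3 sits at a limit, the expectation is that compound 4 remains in the tolerated region, with any shift being none beyond the scatter of this assay and the result possibly read as a number rather than a limit. The expected step is a step that the limit leaves unreadable from compound 3 to compound 4. Compound 4 is therefore estimated at 15000 nM in this assay, within a range from 5000 nM to 40000 nM.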

Compound 4, half-maximal cytotoxic concentration: > 10000 nM
Compound 4: a limit, no number; the forecaster's own chance of this, stated with the estimate: 50%; the middle value is on the limit's open side.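

Compound 3 and compound 4 both sit at the same limit of the assay, not at numbers, so no step can be read from compound 3 to compound 4: the limit of > 10000 nM in this assay, at which 2 of the 4 values shown sit.

The compounds shown leave open how far 2-hydroxy-1-phenylethyl in place of 4-(carboxymethoxy)benzyl on an amine nitrogen shifts the half-maximal cytotoxic concentration in this assay, or whether it shifts it at all.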